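Isopropyl for Methyl Beside a Solubility Limit

A few compounds are considered here, and "the series" means these few. Any claim that something is new, unique, unknown or untested is made for them only; others in the source may bear on it.

In a physicochemical assay for solubility, in the presence of a further agent that is not named here (on this read-out lower numbers stand for lower solubility and higher numbers for higher solubility), three compounds have been measured:
Compound 1 `Cc1ccc2c(c1)[n+]([O-])c(N)n[n+]2[O-]` gives 3000000 nM.
Compound 2 `Cc1ccc2c(c1)[n+]([O-])c(NCCN(C)C)n[n+]2[O-]` gives > 51000000 nM.
Compound 3 `CCCN(CCC)CCNc1n[n+]([O-])c2ccc(C)cc2[n+]1[O-]` gives 38000000 nM.

The value of compound 2 is a limit of this assay and not a number; it is the limit of > 51000000 nM in this assay, at which 1 of the 3 values shown sits. Compound 2 therefore stands at the top of what this assay reports, and its true solubility is not known. Of the two measured steps, an at least 17-fold higher number from compound 1 to compound 2 (1.23 log units; beyond the scatter) is the only one beyond the scatter, while an at least 1.3-fold lower number from compound 2 to compound 3 (0.12 log units; that floor lies within the scatter) has a floor that lies within it.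

Compound 4 `CC(C)c1ccc2c(c1)[n+]([O-])c(NCCN(C)C)n[n+]2[O-]` differs from compound 2 in one place: isopropyl in place of methyl on an aromatic carbon. Neither measured step touches that position. Going by the values given here, the first of them alters the substituent on the nitrogen on the aromatic ring, and the second alters the amine on the saturated chain; nothing measured so far changes the group on the aromatic carbon. There is thus no direct guide for compound 4 among the numbers shown.

Compound 4 is expected to give 40000000 nM in this assay, with a range from 12000000 nM to 80000000 nM. That expectation amounts to an estimated step of an at least 1.2-fold lower number from compound 2 to compound 4 (0.10 log units; that floor lies within the scatter), and a real chance remains that compound 4 also returns only a limit.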

Compound 4, solubility: 42000000 nM
The estimate for compound 4 lay 1.1-fold (0.02 log units) below the measured number, and the stated range covers the measured number.
By their numbers in this assay, from the lowest: compound 1; then compounds 3 and 4 (each within the scatter of the next). At a limit, above all of these: compound 2.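

Going by these compounds alone, the position on the aromatic carbon, which no earlier step touched, now has a measured change: in this assay, isopropyl in place of methyl gives an at least 1.2-fold lower number from compound 2 to compound 4 (0.08 log units; that floor lies within the scatter). Compound 4, carrying isopropyl on the same dimethylamino chain, returns an actual number, 42000000 nM, so the read-out at this position can be given as a value with the larger of the two groups. The value of compound 2 is a limit and not a number, so this step has only a floor, which lies within the scatter, and it shows neither a real drop nor the absence of one: the limit of > 51000000 nM in this assay, at which 1 of the 4 values shown sits.

The compounds shown leave open how a hydroxyl group, an amine or a carboxylic acid on this aromatic carbon would read in this assay, since methyl and isopropyl are the only two groups seen there. They also leave open whether isopropyl would give a similar picture with the dipropylamino chain of compound 3 or with the plain amino group of compound 1.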